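Difluorophenyl replacing methoxyphenyl on the shared core

The source may hold more compounds than are shown below. What is called first, only, known or untested is meant among the compounds shown, and "the series" means these compounds.

Compound 1 `O=C(Nc1ccc(Oc2ccnc3[nH]ccc23)cc1)c1ccc(-c2ccc(Cl)cc2)cn1` and compound 2 `COc1ccc(-c2ccc(C(=O)Nc3ccc(Oc4ccnc5[nH]ccc45)cc3)nc2)cc1` share one core and differ only in one group. In a functional assay on MCF7 cells (Homo sapiens) for cytotoxicity, read by MTT assay, with a stated time of 72 h (a lower number here means a stronger inhibitor, a higher number a weaker inhibitor), compound 1 reaches only the limit > 10000 nM. In this assay compound 2 likewise stops at the limit > 10000 nM. The step that the two limits leave unreadable from compound 1 to compound 2 therefore cannot be read. For the measured compounds named here, compound 2 thus stands at a limit and not at a number, and the one further value shown for the series is a limit as well, so the limit of > 10000 nM in this assay, at which 2 of the 2 values shown sit, is all the evidence there is. Compound 3 `O=C(Nc1ccc(Oc2ccnc3[nH]ccc23)cc1)c1ccc(-c2ccc(F)cc2F)cn1` differs from compound 2 in one place: 2,4-difluorophenyl in place of 4-methoxyphenyl on an aromatic carbon. Going by the values given here, no measured step in this assay bears on this change, since the only step available is unreadable. Compound 3 is expected to sit at the limit once more, so the estimated step that the limit leaves unreadable from compound 2 to compound 3 is none beyond the scatter. For compound 3 the expected value is 15000 nM, within 5000 nM to 50000 nM.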

Compound 3, half-maximal inhibitory concentration: > 10000 nM
Compound 3 gave a limit, no number (the forecaster's own chance of this, stated with the estimate: 70%); the middle value lies beyond the limit too.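

Compound 1, compound 2 and compound 3 each give a limit and not a number, so no step among them can be read in this assay: the limit of > 10000 nM in this assay, at which 3 of the 3 values shown sit.

The compounds shown leave open which numerical value, if any, each of the three would reach in this assay, and how the aryl groups compare.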